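Oxalyl Amide in Place of a Piperidinylmethyl Group

The source may report more compounds than this note shows. Statements on the series, on what has been measured and on what is new or still open speak of the compounds shown alone.

Three compounds of one shared core have been measured in a functional assay on the whole organism (strain albino) for inhibition, with Rattus norvegicus as the target, read by paw edema, with stated times of 1 h and 3 h, at a dose of 20 mmol/kg by the intraperitoneal route; a lower number here means a weaker effect, a higher number a stronger effect of the compound at the dose given:

compound 1 `N#CC1=C(NCC(=O)O)N(c2ccccc2)C(=O)N2CCCCC(N3CCCC3)C12`, 89.2%
compound 2 `N#CC1=C(NCN2CCCCC2)N(c2ccccc2)C(=O)N2CCCCC(N3CCCC3)C12`, 42.1%
compound 3 `N#Cc1c2n(c(=O)n(-c3ccccc3)c1=N)CCCCC2N1CCCC1`, 93.4%

Among these three numbers compound 2 stands lowest. Its nearest neighbour is compound 1, which lies higher by more than the scatter, and compound 3 lies further above it still. Within the data shown here, the only step between compounds that differ in one place is a number 47.1 percentage points lower from compound 1 to compound 2 (beyond the scatter), in which piperidin-1-yl replaced carboxy on a saturated chain carbon bound to an amine nitrogen.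

Compound 4 `COC(=O)C(=O)NC1=C(C#N)C2C(N3CCCC3)CCCCN2C(=O)N1c1ccccc1` has not yet been measured. It departs from compound 2 by (methoxycarbonyl)carbonyl in place of (piperidin-1-yl)methyl on an amine nitrogen. Among the measured compounds shown here, the group that leaves is the one that entered between compound 1 and compound 2, and the group that enters, like the carboxy of compound 1, is made of carbon and oxygen without a ring. That single large step is the only measured one bearing on the change. Read as a pointer, it suggests the number should move upward from compound 2, though the entering group is not the carboxy of compound 1 and a full return cannot be assumed. Compound 4 is therefore expected to give 70%, within 45% to 90%. The step this estimate means is a number 27.9 percentage points higher from compound 2 to compound 4 (beyond the scatter), expected to lie beyond the scatter.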

Compound 4, a percentage reported as inhibition, in the whole organism at one dose (the size of the read-out at that dose, not a potency): 88.3%
Compound 4: middle estimate off by 18.3 percentage points, on the low side, and the stated range covers the measured number.
By their numbers in this assay, from the lowest: compound 2; then compounds 4, 1 and 3 (each within the scatter of the next).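

In this assay, among these compounds, the replacement of (piperidin-1-yl)methyl by (methoxycarbonyl)carbonyl on the amine nitrogen gives a number 46.2 percentage points higher from compound 2 to compound 4 (beyond the scatter) and so adds a second step from compound 2 to the one already seen with compound 1. The other comparison, a number 0.9 percentage points lower from compound 1 to compound 4 (within the scatter), places the carboxymethyl group and the (methoxycarbonyl)carbonyl group within the scatter of each other, even though the two differ in their atoms, so among compounds 1, 2 and 4 only the compound carrying (piperidin-1-yl)methyl stands apart, and it does so on the low side. Nothing measured here explains why the piperidine-bearing group goes with the lower number.

As far as these compounds go, whether that low number goes with the ring, with its nitrogen or with the whole group remains open, and a cyclohexylmethyl group or an open-chain dimethylaminomethyl group on the same amine nitrogen would help to separate these readings. From the compounds shown here alone, it is also open whether a simple acetyl group would stand with compound 1 and compound 4, or whether the methyl ester of compound 4 survives intact in the animal.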